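The compounds below may be only part of what the source reports. "The series", "measured", "known", "first", "only" and "open" are said of these compounds alone.

Measured compounds:
compound 1 `C=C1CC[C@@H]2[C@](C)(COC(C)=O)[C@H](OC(C)=O)CC[C@@]2(C)[C@H]1CC(Nc1ccc(S(=O)(=O)Nc2cc(C)on2)cc1)C1=CCOC1=O`: 38600 nM
compound 2 `C=C1CC[C@@H]2[C@](C)(COC(C)=O)[C@H](OC(C)=O)CC[C@@]2(C)[C@H]1CC(Nc1ccc(S(=O)(=O)Nc2ncccn2)cc1)C1=CCOC1=O`: 9390 nM

In a functional assay on CAKI-1 cells (Homo sapiens) for inhibition, read by sulforhodamine B assay, with a stated time of 48 h (a lower number here means that less compound is tolerated, a higher number that more compound is tolerated), compound 1 gives 38600 nM, the highest of the two numbers at hand. For the measured compounds named here, its only neighbour is compound 2, which in this assay gives 9390 nM; the step of a 4.1-fold lower number from compound 1 to compound 2 (0.61 log units; beyond the scatter) comes from exchanging the group on the sulfonamide nitrogen while the shared core stays untouched.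

Compound 3 `C=C1CC[C@@H]2[C@](C)(COC(C)=O)[C@H](OC(C)=O)CC[C@@]2(C)[C@H]1CC(Nc1ccc(S(=O)(=O)Nc2nccs2)cc1)C1=CCOC1=O` has not yet been tested in this assay. It differs from compound 1 by 1,3-thiazol-2-yl in place of 5-methyl-1,2-oxazol-3-yl on a sulfonamide nitrogen. Going by the values given here, the one measured step that bears on this change is the step of a 4.1-fold lower number from compound 1 to compound 2 (0.61 log units; beyond the scatter), which also replaces the group on the sulfonamide nitrogen by another small heteroaromatic ring and gave a modest move downward. Since the change from compound 1 to compound 3 is of the same kind, a downward move of similar or smaller size is expected, though a result within the scatter cannot be ruled out.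

For compound 3 in this assay the estimate is 16000 nM, expected to lie between 5500 nM and 45000 nM. This estimate corresponds to an expected step of a 2.4-fold lower number from compound 1 to compound 3 (0.38 log units; beyond the scatter).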

Compound 3, concentration lethal to 50% of the cells: 37700 nM
Beside the measured number, compound 3's estimate is 2.4-fold (0.37 log units) below it, and the stated range covers the measured number.
By their numbers in this assay, from the lowest: compound 2; then compounds 3 and 1 (each within the scatter of the next).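

In this assay, the sulfonamide nitrogen accepts 1,3-thiazol-2-yl in place of 5-methyl-1,2-oxazol-3-yl with a 1.0-fold lower number from compound 1 to compound 3 (0.01 log units; within the scatter), so exchanging one small heteroaromatic group for another at this place does not by itself move the number. The earlier step to pyrimidin-2-yl therefore no longer reads as a general result of replacing 5-methyl-1,2-oxazol-3-yl: a 4.0-fold higher number from compound 2 to compound 3 (0.60 log units; beyond the scatter) shows that compound 2 alone gives the lowest number of the three, while compound 1 and compound 3, each with a five-membered aromatic ring with 2 hetero atoms on the nitrogen, cannot be told apart. No supporting evidence is available to explain why pyrimidin-2-yl stands apart from the two other groups.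

Going by these compounds, with so few compounds, it remains open whether the lower number belongs to pyrimidin-2-yl specifically or would also appear with another group on this nitrogen, such as pyridin-2-yl or plain phenyl. On these data alone, it is equally open whether a methyl group added to the 1,3-thiazol-2-yl ring, or a 1,3,4-thiadiazol-2-yl group in its place, would leave the number where compound 3 has it.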